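Cytotoxicity Limits Hold Across Three Analogues; A Thiophene Follows

The compounds below may be only part of what the source reports. "The series", "measured", "known", "first", "only" and "open" are said of these compounds alone.

compound 1 `COC(=O)N[C@H](C(=O)NN(CCC[C@@](O)(Cc1ccccc1)C(=O)N[C@H]1c2ccccc2C[C@H]1O)Cc1ccc(Cl)cc1)C(C)(C)C`: in an ADME assay on MT4 cells (Homo sapiens) for cytotoxicity (a lower number here means that less compound is tolerated, a higher number that more compound is tolerated), compound 1 gives > 10000 nM, a limit of the assay.
compound 2 `COC(=O)N[C@H](C(=O)NN(CCC[C@@](O)(Cc1ccccc1)C(=O)N[C@H]1c2ccccc2C[C@H]1O)CC(C)C)C(C)(C)C`: in this assay compound 2 gives > 10000 nM, a limit of the assay.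
compound 3 `COC(=O)N[C@H](C(=O)NN(CCC[C@@](O)(Cc1ccccc1)C(=O)N[C@H]1c2ccccc2C[C@H]1O)Cc1ccc(-c2cncnc2)cc1)C(C)(C)C`: in this assay compound 3 gives > 10000 nM, a limit of the assay.

Compound 3 therefore stands at the ceiling of this assay, where every measured value sits (the limit of > 10000 nM in this assay, at which 3 of the 3 values shown sit). Compound 4 `COC(=O)N[C@H](C(=O)NN(CCC[C@@](O)(Cc1ccccc1)C(=O)N[C@H]1c2ccccc2C[C@H]1O)Cc1ccc(-c2ccsc2)cc1)C(C)(C)C` departs from compound 3 by a single change: thiophen-3-yl in place of pyrimidin-5-yl on an aromatic carbon. The steps among the measured compounds, a step that the two limits leave unreadable from compound 1 to compound 2, a step that the two limits leave unreadable from compound 1 to compound 3 and a step that the two limits leave unreadable from compound 2 to compound 3, all run between two limits, so none of them has a readable size and none tells how much the group on the saturated chain carbon bound to the amine nitrogen matters for tolerance. With every measured value at the same limit, compound 4 is expected to stay at that limit too, and the step that the limit leaves unreadable from compound 3 to compound 4 is expected to be none beyond the scatter. Compound 4 is estimated at 15000 nM, with a range from 7000 nM to 40000 nM.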

Compound 4, half-maximal cytotoxic concentration: > 10000 nM
Compound 4: only a limit was reported; the forecaster's own chance of this, stated with the estimate: 85%; the middle value does not contradict the limit.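

Compound 4 gives > 10000 nM in this assay, again a limit of the assay. Its steps from compound 1, compound 2 and compound 3 all run between two limits, and none can be read. The compounds shown leave open at what concentration any of them becomes toxic to these cells, and whether swapping pyrimidin-5-yl for thiophen-3-yl changes tolerance at all.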